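Removing a Methoxy Group: Two Cytotoxicity Readings and One Expectation

The source may hold more compounds than are shown below. What is called first, only, known or untested is meant among the compounds shown, and "the series" means these compounds.

Measured compounds:
compound 1 `N/N=C1\NCCN1c1ccccc1Cl` gives 22%
compound 2 `COc1ccc(N2CCN/C2=N\N)cc1` gives 17%

Both were tested in a functional assay on T47D cells (Homo sapiens) for cytotoxicity, with a stated time of 72 h, tested at 10 ug/mL; on this read-out higher numbers stand for a stronger effect at the one concentration tested and lower numbers for a weaker effect. Compound 2 has the lower of the two numbers, but compound 1 sits only a small distance above it, and that gap lies within the usual scatter of repeated measurements, so the two readings cannot be told apart with confidence.

Compound 3 `N/N=C1\NCCN1c1ccccc1` has not yet been measured. It differs from compound 2 by hydrogen in place of methoxy on an aromatic carbon, so that a hydrogen now sits on an aromatic carbon of a six-membered aromatic ring of carbon only. Within the data shown here, no comparable step between measured compounds is available, so the effect of this change on this assay is unknown. Given that compound 2 gives 17% and compound 1 gives 22%, both modest, the expectation for compound 3 is a step of a number 1 percentage points higher from compound 2 to compound 3 (within the scatter), that is, no change beyond the scatter. Compound 3 is therefore estimated at 18%, within a range from 5% to 32%.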

Compound 3, a percentage reported as inhibition, at one concentration (the size of the read-out at that concentration, not a potency): 0%
Compound 3: the middle estimate sits 18 percentage points above what was measured; the whole stated range lies above it.
By their numbers in this assay, from the lowest: compound 3; then compounds 2 and 1 (each within the scatter of the next).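

In this assay, hydrogen in place of methoxy on an aromatic carbon, para to a group of 7 heavy atoms, gives a number 17 percentage points lower from compound 2 to compound 3 (beyond the scatter). Hydrogen in place of chloro on an aromatic carbon gives a number 22 percentage points lower from compound 1 to compound 3 (beyond the scatter). Until now, neither group could be compared with a bare ring; these steps show that, among these three compounds, the modest reading is present with either group and absent without one, as compound 3 gives 0%.

Going by these compounds, it remains open whether an amine or a carboxylic acid at the methoxy position would also give a reading, and whether a longer chain such as ethoxy would change its size. Nothing available explains why removing either group has this effect.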